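Swapping methoxy for methyl on the nitrogen-bound ring

The source may hold more compounds than are shown below. What is called first, only, known or untested is meant among the compounds shown, and "the series" means these compounds.

Measured so far:
compound 1 `Cc1cc2occ(-c3nc(-c4ccccc4)c(-c4ccccc4)n3-c3cccc(Cl)c3)c(=O)c2cc1Cl`: 25000 nM
compound 2 `Cc1ccc(-n2c(-c3coc4cc(C)c(Cl)cc4c3=O)nc(-c3ccccc3)c2-c2ccccc2)c(C)c1`: 3120 nM
compound 3 `COc1cccc(-n2c(-c3coc4cc(C)c(Cl)cc4c3=O)nc(-c3ccccc3)c2-c2ccccc2)c1`: 6250 nM

In a functional assay on HepG2 cells (Homo sapiens) for inhibition, read by MTT assay, with a stated time of 72 h (on this read-out higher numbers stand for weaker inhibition and lower numbers for stronger inhibition), compound 3 gives 6250 nM, the second highest of the three numbers; it is beyond the scatter away from compound 1 (a 4.0-fold lower number from compound 1 to compound 3 (0.60 log units; beyond the scatter)) but within it of compound 2 (a 2.0-fold higher number from compound 2 to compound 3 (0.30 log units; within the scatter)). Compound 4 `Cc1cccc(-n2c(-c3coc4cc(C)c(Cl)cc4c3=O)nc(-c3ccccc3)c2-c2ccccc2)c1` differs from compound 3 in one place: methyl in place of methoxy on an aromatic carbon. Among the compounds with values here, no measured step tests methoxy against methyl directly. Compound 2, which carries methyls on that ring, gives 3120 nM, and a 4.0-fold lower number from compound 1 to compound 3 (0.60 log units; beyond the scatter) shows this position can move the number. A small step is therefore expected, a 1.4-fold lower number from compound 3 to compound 4 (0.14 log units; within the scatter), likely within the scatter. Compound 4 is estimated at 4500 nM, between 2000 nM and 10000 nM.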

Compound 4, half-maximal inhibitory concentration: 6250 nM
Estimate against measurement, compound 4: 1.4-fold (0.14 log units) below; the range from low to high includes it.
By their numbers in this assay, from the lowest: compounds 2, 3 and 4 (each within the scatter of the next); then compound 1.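

Methyl in place of methoxy gives no change at the digits printed from compound 3 to compound 4 (within the scatter) and so offers the first direct test of these two groups on this ring. Moving from 2,4-dimethylphenyl to 3-methylphenyl gives a 2.0-fold higher number from compound 2 to compound 4 (0.30 log units; within the scatter) and likewise stays within the usual scatter. Only the chloro compound stands apart, with a 4.0-fold lower number from compound 1 to compound 4 (0.60 log units; beyond the scatter) showing that methyl and methoxy read alike here while chloro does not. No evidence is available to explain these numbers. Still open, as far as these compounds go, is how an amine or a carboxylic acid at this place would read.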